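This account rests on a few compounds, and the source may have more. Where it says the series, first, only, none or still open, it means among the compounds named here.

Measured compounds:
- compound 1 `COc1cccc(/C=C/c2ccc(F)cc2)c1` gives 6000 nM in an assay on HepG2 cells for activation of nuclear factor erythroid 2-related factor 2 (Homo sapiens), read by a luciferase reporter, with a stated time of 5 h; a higher number here means that more compound is needed for the effect, a lower number that less compound is needed
- compound 2 `COc1cccc(/C=C/c2ccc(F)cc2)c1OC` gives 2900 nM in this assay
- compound 3 `Fc1ccc(/C=C/c2cc(F)ccc2F)cc1` gives 2900 nM in this assay

On these numbers compound 2 sits level with compound 3 at the digits shown, the two together the lowest of the three values. Among the compounds with values here, the only single-point step measured so far is a 2.1-fold lower number from compound 1 to compound 2 (0.32 log units; beyond the scatter), a modest gain. Compound 2 and compound 3 differ in more than one place, so their equal values are noted but not read as a step.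

Compound 4 `COc1cccc(/C=C/c2ccc(C)cc2)c1OC` is not yet measured. It differs from compound 2 by methyl in place of fluoro on an aromatic carbon. Within the data shown here, no measured step changes a fluoro to a methyl, so nothing here speaks directly to the size or direction of this change. In the absence of a bearing step, the expectation for compound 4 in this assay is a value close to that of compound 2, with no step beyond the scatter: the step from compound 2 to compound 4 is estimated as a 1.0-fold higher number from compound 2 to compound 4 (0.01 log units; within the scatter). Compound 4 is thus estimated at 3000 nM, with a range of 1200 nM to 7500 nM.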

Compound 4, half-maximal effective concentration: 1100 nM
Beside the measured number, compound 4's estimate is 2.7-fold (0.44 log units) above it; measured number below the stated range.
By their numbers in this assay, from the lowest: compound 4; then compounds 2 and 3 (each within the scatter of the next); then compound 1.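

Methyl in place of fluoro on an aromatic carbon, para to a large group, gives a 2.6-fold lower number from compound 2 to compound 4 (0.42 log units; beyond the scatter) in this assay. This shows that the place para to a large group responds to an exchange of one heavy atom for another, which the earlier step, a methoxy in place of hydrogen elsewhere on the core, could not show. The step is modest but beyond the scatter, and no available data account for it.

Going by these compounds, with only fluoro and methyl compared at this place, it remains open whether an ethyl group, a longer chain, an amine or a carboxylic acid would lower the number further or raise it. On these data alone, it is also open whether methyl in place of fluoro would give a similar step on the core of compound 1, which lacks the second methoxy.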